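This account rests on a few compounds, and the source may have more. Where it says the series, first, only, none or still open, it means among the compounds named here.

Measured compounds:
compound 1 `Clc1ccc(C2CC(c3ccccc3)=NN2c2ccc(-c3ccccc3)nn2)cc1`, 100000 nM
compound 2 `FC(F)(F)c1ccc(C2CC(c3ccccc3)=NN2c2ccc(-c3ccccc3)nn2)cc1`, 100000 nM

In a functional assay on MCF7 cells (Homo sapiens) for antiproliferative activity, read by MTT assay, with a stated time of 24 h (a lower number here means a stronger inhibitor, a higher number a weaker inhibitor), compound 1 gives 100000 nM. Compound 2, which carries trifluoromethyl in place of chloro on an aromatic carbon, gives 100000 nM in this assay, so compound 1 stands level with compound 2 at the digits shown, and the step of no change at the digits printed from compound 1 to compound 2 (within the scatter) is within the scatter.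

Compound 3 `COc1ccc(C2CC(c3ccccc3)=NN2c2ccc(-c3ccccc3)nn2)c(OC)c1` is the unmeasured member of the set. Its change from compound 1 is 2,4-dimethoxyphenyl in place of 4-chlorophenyl on a saturated ring carbon, a 2,4-dimethoxyphenyl in place of 4-chlorophenyl on a saturated ring carbon, with the rest of the shared core left untouched. Among the measured compounds shown here, the only measured step that bears on this position is no change at the digits printed from compound 1 to compound 2 (within the scatter), and it showed no change beyond the scatter when one aromatic substituent gave way to another. On that basis no step beyond the scatter is expected in this assay for compound 3 either, though the new group differs more from chloro than trifluoromethyl did. Compound 3 is therefore estimated at 100000 nM, with a range from 30000 nM to 100000 nM, which means an expected step of no change at the digits printed from compound 1 to compound 3 (within the scatter).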

Compound 3, half-maximal inhibitory concentration: > 100000 nM
Compound 3: a limit, no number; the forecaster's own chance of this, stated with the estimate: 40%; the middle value lies on the limit itself.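

In this assay compound 3 gives > 100000 nM, which is a limit of the assay and not a number. With 2,4-dimethoxyphenyl in place of 4-chlorophenyl on the saturated ring carbon, the earlier result now extends to a group that differs more from the one it replaces: an aromatic ring carrying hydrogen-bond acceptors also shows a number no lower from compound 1 to compound 3 (the limit leaves the size open) and a number no lower from compound 2 to compound 3 (the limit leaves the size open). The sizes of the steps from compound 1 and compound 2 to compound 3 cannot be read, because the value of compound 3 is a limit: the limit of > 100000 nM in this assay, at which 1 of the 3 values shown sits.

The compounds shown therefore give no readable number that would rank these groups, and they leave open whether any group at this position can bring a lower number in this assay. In particular, they do not tell what a phenyl ring bearing an amine or a carboxylic acid on this saturated ring carbon would give.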